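A few compounds are considered here, and "the series" means these few. Any claim that something is new, unique, unknown or untested is made for them only; others in the source may bear on it.

Measured so far: compound 1 `O=C(NCc1ccc(S(=O)(=O)c2cccc(C(F)(F)F)c2)cc1)N1Cc2ccncc2C1` gives 14 mL/min/kg in an ADME assay on microsomes from liver (Homo sapiens) for pharmacokinetics, read by LC-MS, with a stated time of 60 min, tested at 1 uM; a lower number here means slower removal, a higher number faster removal of the compound; compound 2 `O=C(NCc1ccc(S(=O)(=O)c2cc(F)cc(F)c2)cc1)N1Cc2ccncc2C1` gives 8 mL/min/kg.

For the measured compounds named here, compound 1 stands highest of the two numbers, but its only neighbour, compound 2, lies within the scatter of it: a 1.8-fold lower number from compound 1 to compound 2 (0.24 log units; within the scatter). Compound 3 `O=C(NCc1ccc(S(=O)(=O)C2CCCOC2)cc1)N1Cc2ccncc2C1` differs from compound 1 in one place: oxan-3-yl in place of 3-(trifluoromethyl)phenyl on a sulfonyl sulfur. Going by the values given here, no measured step exchanges the aromatic ring for a non-aromatic one, so only the step from compound 1 to compound 2, which stays within the scatter, bears on it at all. He therefore expects for compound 3 a number near compound 1, with a 1.3-fold lower number from compound 1 to compound 3 (0.10 log units; within the scatter) beyond the scatter not anticipated, estimating 11 mL/min/kg between 5 mL/min/kg and 24 mL/min/kg.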

Compound 3, clearance: 7 mL/min/kg
The estimate for compound 3 lay 1.6-fold (0.20 log units) above the measured number; measured number inside the range.
By their numbers in this assay, from the lowest: compounds 3, 2 and 1 (each within the scatter of the next).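

In this assay the exchange for a non-aromatic ring on the sulfonyl sulfur gives a 2.0-fold lower number from compound 1 to compound 3 (0.30 log units; within the scatter) and a 1.1-fold lower number from compound 2 to compound 3 (0.06 log units; within the scatter) so oxan-3-yl stays within the scatter of both aromatic groups. Among these three compounds, then, an aromatic ring on this sulfur is not needed for numbers of this size. Nothing available gives a reason for this result.

The compounds shown leave open whether an amine, a carboxylic acid or an open alkyl chain on this sulfur would move the number beyond the scatter.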